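Trading the Chloro on the Phenyl for a Bromo

A few compounds are considered here, and "the series" means these few. Any claim that something is new, unique, unknown or untested is made for them only; others in the source may bear on it.

Compound 2 `CC1=C(/C=C/C(=O)/C=C/c2ccc(Cl)cc2)C(C)(C)CCC1` gives the highest number of the three measured compounds in a functional assay on IMR-32 cells (Homo sapiens) for cytotoxicity, read by sulforhodamine B assay, with a stated time of 48 h (a higher number here means a weaker inhibitor, a lower number a stronger inhibitor), at 52300 nM. Compound 1 `CC1=C(/C=C/C(=O)/C=C/c2ccccc2)C(C)(C)CCC1` gives 20400 nM, and compound 3 `CC1=C(/C=C/C(=O)/C=C/c2ccc(C#N)cc2)C(C)(C)CCC1` gives 23400 nM. Compound 4 `CC1=C(/C=C/C(=O)/C=C/c2ccccc2Br)C(C)(C)CCC1` carries 2-bromophenyl in place of 4-chlorophenyl on a double-bonded chain carbon bound to a double-bonded chain carbon. Among the measured compounds shown here, no measured step involves a bromo group, so only the steps that put in or take out the chloro bear on this change: a 2.6-fold higher number from compound 1 to compound 2 (0.41 log units; beyond the scatter) and a 2.2-fold lower number from compound 2 to compound 3 (0.35 log units; beyond the scatter), both modest. Since both measured changes to the chloro moved the number only modestly, compound 4 is expected to show a 2.0-fold lower number from compound 2 to compound 4 (0.30 log units; within the scatter) in this assay. Compound 4 is therefore estimated at 26000 nM, with a likely range from 12000 nM to 60000 nM.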

Compound 4, half-maximal inhibitory concentration: 16300 nM
Beside the measured number, compound 4's estimate is 1.6-fold (0.20 log units) above it, within the range that was stated.
By their numbers in this assay, from the lowest: compounds 4, 1 and 3 (each within the scatter of the next); then compound 2.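

In this assay, swapping the 4-chlorophenyl for the 2-bromophenyl gives the largest single change seen so far (a 3.2-fold lower number from compound 2 to compound 4 (0.51 log units; beyond the scatter)), while adding the bromo to the plain phenyl ring leaves the number within the scatter (a 1.3-fold lower number from compound 1 to compound 4 (0.10 log units; within the scatter)). So a halogen on this ring does not always raise the number: compound 2 does, compound 4 does not. Nothing measured here explains this difference. As far as these compounds go, since the halogen and its place on the ring change together, the step cannot separate the two, and how an amine or a methoxy group on this ring would read remains open.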